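A few compounds are considered here, and "the series" means these few. Any claim that something is new, unique, unknown or untested is made for them only; others in the source may bear on it.

The three measured compounds, all tested in an ADME assay on HepG2 cells (Homo sapiens) for cytotoxicity, read by luminescence, CellTiter-Glo and ATP content, with a stated time of 72 h; a higher number here means that more compound is needed for the effect, a lower number that less compound is needed:

Compound 1, `COc1ccc(F)cc1CNCCCNc1ccnc2cc(Cc3ccc(F)cc3)ccc12`, gives 3530 nM.
Compound 2, `COc1cccc(CNCCCNc2ccnc3cc(-c4ccccc4)ccc23)c1O`, gives 3210 nM.
Compound 3, `COc1cccc(CNCCCNc2ccnc3cc(Oc4ccccc4)ccc23)c1O`, gives 6800 nM.

Compound 3 has the highest of the three numbers. Among the measured compounds shown here, its gap to compound 1 lies within the scatter, so the two cannot be told apart; the only measured step that reaches it is a 2.1-fold higher number from compound 2 to compound 3 (0.33 log units; beyond the scatter), a modest rise when phenoxy replaced phenyl.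

Compound 4, `COc1cccc(CNCCCNc2ccnc3cc(Cc4ccc(F)cc4)ccc23)c1O`, differs from compound 3 in one place: 4-fluorobenzyl in place of phenoxy on an aromatic carbon.

For the measured compounds named here, no measured step shows this exact change on a shared core, so the expectation rests on what the other compounds show. Compound 1 carries the same 4-fluorobenzyl group on its core and sits within the scatter of compound 3, while compound 2, with phenyl, lies modestly below compound 3. Taken together, compound 4 is expected to move a little downward from compound 3, by about a 1.9-fold lower number from compound 3 to compound 4 (0.28 log units; within the scatter), landing near the values of compound 1 and compound 2. The estimate for compound 4 in this assay is 3600 nM, with a likely range from 1800 nM to 7200 nM.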

Compound 4, half-maximal effective concentration: 4780 nM
The estimate for compound 4 lay 1.3-fold (0.12 log units) below the measured number; low and high end bracket the measured number.
By their numbers in this assay, from the lowest: compounds 2, 1, 4 and 3 (each within the scatter of the next, the first and the last beyond it).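

In this assay, 4-fluorobenzyl on this aromatic carbon gives a 1.4-fold lower number from compound 3 to compound 4 (0.15 log units; within the scatter) and, measured against the phenyl group, a 1.5-fold higher number from compound 2 to compound 4 (0.17 log units; within the scatter) so compound 4 cannot be told apart from either of the other two compounds on the shared core, even though those two differ from each other beyond the scatter. Among the compounds shown here, the 4-fluorobenzyl group therefore adds a third substituent at this position without showing a separate effect of its own, and the one step here that exceeds the scatter remains the change from phenyl to phenoxy. The change at the other end of the molecule, 2-hydroxy-3-methoxyphenyl in place of 5-fluoro-2-methoxyphenyl with 4-fluorobenzyl held constant, gives a 1.4-fold higher number from compound 1 to compound 4 (0.13 log units; within the scatter) and so also leaves no readable difference, while nothing available offers an explanation for any of these numbers.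

The compounds shown leave open whether a plain benzyl group, lacking the fluorine, would read differently from 4-fluorobenzyl at this position. They also leave open whether an amine or a carboxylic acid on the same aromatic carbon would move the number clearly beyond the scatter.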